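Phthalide series: nitric oxide inhibition working notes

The source may hold more compounds than are shown below. What is called first, only, known or untested is meant among the compounds shown, and "the series" means these compounds.

Measured compounds:
compound 1 `O=C1OC(Cc2nc(-c3ccccc3)no2)c2ccccc21`; in a functional assay on RAW264.7 cells (Mus musculus) for inhibition, read by Griess assay, with stated times of 1 h and 24 h (on this read-out lower numbers stand for stronger inhibition and higher numbers for weaker inhibition), compound 1 gives > 10000 nM, a limit of the assay.
compound 2 `O=C1OC(Cc2nc(Cc3ccccc3)no2)c2ccccc21`; in this assay compound 2 gives > 10000 nM, again a limit of the assay.
compound 3 `COCCCOc1ccc(C(O)C2OC(=O)c3c(OC)cc(OC)cc32)cc1`; in this assay compound 3 gives 1260 nM.

Within the data shown here, compound 3 holds the only number in the set; the other two values stand at the limit of > 10000 nM in this assay, at which 2 of the 3 values shown sit. Among the measured compounds shown here, the single one-point step, from compound 1 to compound 2 a step that the two limits leave unreadable from compound 1 to compound 2, is benzyl in place of phenyl on an aromatic carbon, and both limits leave its size unreadable.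

Compound 4 `COc1cc(OC)c2c(c1)C(C(O)c1ccc(OCc3ccc(C)cc3)cc1)OC2=O` is the next member. Against compound 3 the change is 4-methylphenyl in place of 2-methoxyethyl on a saturated chain carbon bound to an oxygen on an aromatic ring. For the measured compounds named here, no measured step touches this kind of change, and the only measured step in the set gives no size at all, so there is nothing to scale an expectation by. The working assumption is therefore a step estimated at a 1.3-fold lower number from compound 3 to compound 4 (0.10 log units; within the scatter). On that basis compound 4 is estimated at 1000 nM in this assay, with a range from 300 nM to 4000 nM.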

Compound 4, half-maximal inhibitory concentration: 3120 nM
Compound 4: middle estimate off by 3.1-fold (0.49 log units), on the low side, within the range that was stated.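

At the saturated chain carbon bound to an oxygen on an aromatic ring, the series now has its first readable step: in this assay, 4-methylphenyl in place of 2-methoxyethyl gives a 2.5-fold higher number from compound 3 to compound 4 (0.39 log units; beyond the scatter), which means weaker inhibition. Compound 4 still gives a number and not a limit of the assay, so on this one pair the aromatic ring in the entering group does not remove inhibition altogether. No measured property bears on this step, and the notes offer nothing on what lies behind it.

A single pair cannot separate the effect of the ring from that of the other differences between the two groups. From the compounds shown here alone, how an amine, a carboxylic acid or a longer ether chain would read at this place remains open, as does whether an unsubstituted benzyl would differ from 4-methylbenzyl.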